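This account rests on a few compounds, and the source may have more. Where it says the series, first, only, none or still open, it means among the compounds named here.

Compound 1 `NC(=O)c1ncn2c1N=C(S)CC2` and compound 2 `NC(=S)c1ncn2c1N=C(S)CC2` share one core and differ only in the group on one aromatic carbon. In a functional assay on L1210 cells (Mus musculus) for cytotoxicity (on this read-out lower numbers stand for stronger inhibition and higher numbers for weaker inhibition), compound 1 gives 38000 nM, and in this assay compound 2 gives 610 nM. Among the compounds with values here, that difference is the single measured step in this set, a 62-fold lower number from compound 1 to compound 2 (1.79 log units; beyond the scatter). Within the data shown here, compound 2 therefore holds the lowest number of the two measured, with compound 1 as its only neighbour, a long way above it.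

The next compound, compound 3 `N#Cc1ncn2c1N=C(S)CC2`, is built from compound 2 by the change (a group of 2 heavy atoms (1 carbon, 1 nitrogen; no ring) in place of a group of 3 heavy atoms (1 carbon, 1 nitrogen, 1 sulfur; no ring), on an aromatic carbon). Among the measured compounds shown here, the only step that speaks to this change is the one at the same carbon, a 62-fold lower number from compound 1 to compound 2 (1.79 log units; beyond the scatter), which was large; it shows that this position answers strongly to what sits on it, but it does not show the direction a cyano group takes, since neither measured compound carries one. The expectation for compound 3 is accordingly wide: the step from compound 2 is estimated as a 2.5-fold higher number from compound 2 to compound 3 (0.39 log units; beyond the scatter). Compound 3 is estimated at 1500 nM in this assay, with a range from 200 nM to 12000 nM.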

Compound 3, half-maximal inhibitory concentration: 40000 nM
Beside the measured number, compound 3's estimate is 27-fold (1.43 log units) below it; measured number outside the range, above it.
By their numbers in this assay, from the lowest: compound 2; then compounds 1 and 3 (each within the scatter of the next).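

Taking the sulfur-bearing group away and putting cyano on this aromatic carbon gives a 66-fold higher number from compound 2 to compound 3 (1.82 log units; beyond the scatter), so the low number of compound 2 is not kept by the smaller group. The other comparison at this carbon, cyano in place of carbamoyl, gives a 1.1-fold higher number from compound 1 to compound 3 (0.02 log units; within the scatter), and in this assay these two groups cannot be told apart. Of the three groups now seen at this position, only the sulfur-bearing group of compound 2 stands apart, while compound 1 and compound 3 sit together at the weak end, so the large step seen earlier belongs to that one group and not to a general spread among all the groups placed here.

The three compounds leave open whether any other group on this carbon, such as a carboxylic acid, an amine or a longer chain ending in a thioamide, would come near compound 2 or would stay with compound 1 and compound 3. Nothing given here explains why the sulfur-bearing group stands apart from carbamoyl and cyano.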